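Ortho-chloro on the benzyl ether of the shared core

The source may hold more compounds than are shown below. What is called first, only, known or untested is meant among the compounds shown, and "the series" means these compounds.

Measured compounds:
- compound 1 `COc1cc(OC)c(-c2coc3cc(OCc4ccccc4)ccc3c2=O)cc1OC`; in a functional assay on HUVEC cells (Homo sapiens) for antiproliferative activity, read by MTT assay, with a stated time of 24 h (a lower number here means a stronger inhibitor, a higher number a weaker inhibitor), compound 1 gives 9750 nM
- compound 2 `COc1cc(OC)c(-c2coc3cc(OCc4ccccc4C)ccc3c2=O)cc1OC`; in this assay compound 2 gives 4830 nM
- compound 3 `COc1cc(OC)c(-c2coc3cc(OCc4cccc(Cl)c4)ccc3c2=O)cc1OC`; in this assay compound 3 gives > 10000 nM, which is a limit of the assay and not a number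

Among the numbers shown, compound 1 stands highest of the two numbers, with compound 2 nearest at a 2.0-fold lower number from compound 1 to compound 2 (0.31 log units; beyond the scatter). The step to compound 4 `COc1cc(OC)c(-c2coc3cc(OCc4ccccc4Cl)ccc3c2=O)cc1OC` is chloro in place of hydrogen on an aromatic carbon, at a position ortho to a large group on the benzyl ring.

Among the compounds with values here, two measured steps bear on it. Methyl at the same place gave a 2.0-fold lower number from compound 1 to compound 2 (0.31 log units; beyond the scatter). Chloro at another place gave an at least 1.0-fold higher number from compound 1 to compound 3 (0.01 log units; that floor lies within the scatter), and between those two an at least 2.0-fold higher number from compound 2 to compound 3 (0.31 log units; beyond the scatter). The chloro at the other place sits at the limit of > 10000 nM in this assay, at which 1 of the 3 values shown sits.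

For compound 4, chloro at the place where methyl helped, a small gain is expected but not assured; the estimate is 7000 nM, range 3000 nM to 15000 nM, meaning an expected step of a 1.4-fold lower number from compound 1 to compound 4 (0.14 log units; within the scatter).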

Compound 4, half-maximal inhibitory concentration: > 10000 nM
Compound 4 gave a limit, no number (the forecaster's own chance of this, stated with the estimate: 30%); middle value at least 1.4-fold (0.15 log units) away from the limit.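

Chloro in place of methyl gives an at least 2.0-fold higher number from compound 2 to compound 4 (0.31 log units; beyond the scatter), so the gain seen with methyl at this place on the benzyl ring does not carry over to chloro. Against the unsubstituted benzyl ether, chloro gives an at least 1.0-fold higher number from compound 1 to compound 4 (0.01 log units; that floor lies within the scatter), a floor that lies within the scatter, so neither a gain nor a loss can be stated for this change. The step between the two chloro compounds cannot be read, and the places of chloro on the benzyl ring cannot be ranked in this assay: the limit of > 10000 nM in this assay, at which 2 of the 4 values shown sit.

As far as these compounds go, how far compound 3 and compound 4 lie past that limit stays open. Also open, from the compounds shown here alone, is whether an ethyl group or an amine at this place would follow compound 2 or compound 4.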